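This account rests on a few compounds, and the source may have more. Where it says the series, first, only, none or still open, it means among the compounds named here.

Compounds measured in an assay on Cerebral cortex (strain Sprague-Dawley) for displacement of a labelled ligand from Neuronal acetylcholine receptor; alpha4/beta2 (Rattus norvegicus); on this read-out higher numbers stand for weaker inhibition and lower numbers for stronger inhibition:
- compound 1 `CN1CCC[C@H]1[C@@H]1COc2ccc(CO)cc2O1`: 51000 nM
- compound 2 `CN1CCC[C@H]1[C@@H]1COc2ccc(Br)cc2O1`: 8100 nM
- compound 3 `CN1CCC[C@@H]1[C@@H]1COc2ccc(O)cc2O1`: 3000 nM

Compound 1 gives the highest of the three numbers in this assay; its nearest neighbour is compound 2, and compound 3 lies furthest from it. The change from compound 1 to compound 4 `CN1CCC[C@H]1[C@@H]1COc2ccc(O)cc2O1` is hydroxy in place of hydroxymethyl on an aromatic carbon. Going by the values given here, only one measured step touches the same aromatic carbon: a 6.3-fold lower number from compound 1 to compound 2 (0.80 log units; beyond the scatter). Among the compounds with values here, compound 3 carries the same hydroxy group as compound 4 but with a different configuration at the pyrrolidine carbon, and no step between compound 3 and compound 4 has been measured; in this assay compound 3 gives 3000 nM, simply the lowest number in the set. On this basis a shift of the same kind as the bromo step, namely a lower number from compound 1, is expected, estimated as an 11-fold lower number from compound 1 to compound 4 (1.05 log units; beyond the scatter). Compound 4 is therefore expected to give about 4500 nM in this assay, within a range from 1200 nM to 17000 nM.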

Compound 4, inhibition constant: 12 nM
The estimate for compound 4 lay 380-fold (2.57 log units) above the measured number, and the stated range ends above it.
By their numbers in this assay, from the lowest: compound 4; then compound 3; then compound 2; then compound 1.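

In this assay, the hydroxy group on this aromatic carbon sets compound 4 far apart from its two neighbours, with a 4300-fold lower number from compound 1 to compound 4 (3.63 log units; beyond the scatter) and a 680-fold lower number from compound 2 to compound 4 (2.83 log units; beyond the scatter), whereas the earlier compounds had shown only a modest step at this position. The hydroxy group is not enough on its own, as compound 3 carries it too, yet there is a 250-fold lower number from compound 3 to compound 4 (2.40 log units; beyond the scatter). That step is assigned to the stereocentre at a saturated ring carbon, drawn R in compound 3 and S in compound 4, on one ground: the fact that compounds 3 and 4 differ only in the configuration as drawn

The compounds shown do not tell how a methoxy group or an amine on this aromatic carbon would compare with hydroxy. They also leave open whether the bromo and hydroxymethyl compounds respond to the same change of configuration as the hydroxy pair.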